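Moving the Methoxy Group: Compound 2 to Compound 3

The compounds below may be only part of what the source reports. "The series", "measured", "known", "first", "only" and "open" are said of these compounds alone.

Compound 1, `COc1ccccc1-n1cc(CN2C(=O)C[C@@H]3CC[C@@]2(C)C3(C)C)nn1`: 70 nM
Compound 2, `CC1(C)[C@H]2CC[C@]1(C)N(Cc1cn(-c3ccccc3O)nn1)C(=O)C2`: 540 nM

In a functional assay on LoVo cells (Homo sapiens) for inhibition, read by MTT assay, with a stated time of 24 h (on this read-out lower numbers stand for stronger inhibition and higher numbers for weaker inhibition), compound 2 gives 540 nM, the highest of the two numbers; its nearest neighbour, compound 1, gives 70 nM. Going by the values given here, the single measured step, a 7.7-fold higher number from compound 1 to compound 2 (0.89 log units; beyond the scatter), arose from hydrogen in place of methyl on an oxygen on an aromatic ring. Compound 3, `COc1ccc(-n2cc(CN3C(=O)C[C@@H]4CC[C@@]3(C)C4(C)C)nn2)cc1`, is not yet measured. Its change from compound 2 is 4-methoxyphenyl in place of 2-hydroxyphenyl on an aromatic nitrogen. This brings the methyl back onto the oxygen, so the measured step bears on it in reverse, though the whole phenyl group is exchanged here, and for that part of the change nothing has been measured. Compound 3 is therefore expected to return toward the lower number, with the step of a 4.5-fold lower number from compound 2 to compound 3 (0.65 log units; beyond the scatter) estimated to undo much of the earlier rise. The estimate for compound 3 is 120 nM, ranging from 40 nM to 400 nM.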

Compound 3, half-maximal inhibitory concentration: 70 nM
Estimate against measurement, compound 3: 1.7-fold (0.23 log units) above; the measured number falls inside the stated range.
By their numbers in this assay, from the lowest: compounds 1 and 3 (each within the scatter of the next); then compound 2.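

In this assay, 4-methoxyphenyl in place of 2-hydroxyphenyl on the aromatic nitrogen gives a 7.7-fold lower number from compound 2 to compound 3 (0.89 log units; beyond the scatter) and so brings the number back to the level of compound 1. Going by these compounds alone, the comparison of the two methoxy compounds, which differ only in 4-methoxyphenyl against 2-methoxyphenyl, gives no change at the digits printed from compound 1 to compound 3 (within the scatter) and shows that this read-out does not separate these two placements of the methoxy group, leaving 2-hydroxyphenyl in compound 2 as the only group of the three that goes with the higher number. Nothing at hand explains this result.

The compounds shown do not separate the effect of the hydroxy group itself from that of where it stands on the phenyl ring. They also leave open whether an ethoxy group or an amine in place of the methoxy group would keep the number of compound 3.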